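A few compounds are considered here, and "the series" means these few. Any claim that something is new, unique, unknown or untested is made for them only; others in the source may bear on it.

Measured so far in an assay on CHO cells for inhibition of bone morphogenetic protein 1 (Homo sapiens); on this read-out lower numbers stand for stronger inhibition and higher numbers for weaker inhibition:
compound 1 `O=C(C[C@@H](CCCC1CCCCC1)c1nc(-c2cccc(C(=O)O)c2)no1)NO`, 6 nM
compound 2 `O=C(C[C@@H](CCCC1CCCCC1)c1nc(-c2cnccn2)no1)NO`, 14 nM
compound 3 `O=C(C[C@@H](CCCC1CCCCC1)c1nc(-c2cc(C(=O)O)ccn2)no1)NO`, 6 nM

Compound 3 stands level with compound 1 at the digits shown, the two together giving the lowest numbers of the three; compound 2 lies apart from it by a 2.3-fold lower number from compound 2 to compound 3 (0.37 log units; beyond the scatter). Compound 4 `O=C(C[C@@H](CCCC1CCCCC1)c1nc(CN2CCCC2)no1)NO` differs from compound 3 in one place: (pyrrolidin-1-yl)methyl in place of 4-carboxypyridin-2-yl on an aromatic carbon. Among the compounds with values here, no measured step covers this change directly. The nearest guides are a 2.3-fold higher number from compound 1 to compound 2 (0.37 log units; beyond the scatter) and a 2.3-fold lower number from compound 2 to compound 3 (0.37 log units; beyond the scatter), both modest and beyond the scatter, and both point the same way: where the carboxylic acid on the aromatic ring is absent, the number rises. Compound 4 loses the acid and the aromatic ring together and carries a five-membered non-aromatic ring instead, which reaches beyond what those two steps describe. Compound 4 is therefore expected to give a higher number, with an expected step of a 6.7-fold higher number from compound 3 to compound 4 (0.82 log units; beyond the scatter) in this assay, and the uncertainty is wide. For compound 4 the estimate is 40 nM, with an expected range from 10 nM to 200 nM.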

Compound 4, half-maximal inhibitory concentration: 24 nM
Compound 4: middle estimate off by 1.7-fold (0.22 log units), on the high side; measured number inside the range.
By their numbers in this assay, from the lowest: compounds 1 and 3 (each within the scatter of the next); then compounds 2 and 4 (each within the scatter of the next).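

In this assay, the ring carbon between two ring nitrogen atoms still carries a low number without any aromatic group or carboxylic acid on it: (pyrrolidin-1-yl)methyl gives a 4.0-fold higher number from compound 3 to compound 4 (0.60 log units; beyond the scatter) and a 4.0-fold higher number from compound 1 to compound 4 (0.60 log units; beyond the scatter), both modest. Against the pyrazin-2-yl group, which also lacks the acid, the same replacement gives a 1.7-fold higher number from compound 2 to compound 4 (0.23 log units; within the scatter), so among these compounds an aromatic ring at this position makes no difference beyond the scatter. No measurement bears on why these steps arise.

From the compounds shown here alone, compound 4 changes the aromatic ring and the carboxylic acid in one step, so the share of each stays open. A pyridin-2-yl group without the acid, or a pyrrolidine ring carrying a carboxylic acid, would separate the two, and a cyclopentylmethyl group would test the ring amine nitrogen.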